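A few compounds are considered here, and "the series" means these few. Any claim that something is new, unique, unknown or untested is made for them only; others in the source may bear on it.

Working notes on the series, read in a functional assay on T98G cells (Homo sapiens) for cytotoxicity, read by MTT assay, with a stated time of 48 h; a lower number here means a stronger inhibitor, a higher number a weaker inhibitor. Of the compounds shown here, two have numbers so far. Compound 1 (`C/C(=N\NC(=S)Nc1ccc(Cl)cc1)c1ccccn1`) gives 5.9 nM. Compound 2 (`CC(=NNC(=S)Nc1ccccc1F)c1ccccn1`) gives 3.1 nM, and the two numbers lie within the usual scatter of each other, so no order can be read between them.

Compound 3 (`C/C(=N/NC(=S)Nc1ccccc1F)c1ccccn1`) is the next to be read. Its difference from compound 2 is the two compounds have the same atoms and bonds; at least one stereo element is drawn with a configuration in one of them and without one in the other: 1 of 1 stereo elements differ; a double bond is drawn without a configuration in compound 2 and Z in compound 3. The two compounds have the same atoms and bonds, and a double bond is drawn without a configuration in compound 2 and Z in compound 3. Within the data shown here, no measured pair shows a change of this kind, so the data give no step to go by. The expectation therefore rests on compound 2 at 3.1 nM, with no change beyond the scatter in either direction. The expected change is a 1.1-fold higher number from compound 2 to compound 3 (0.05 log units; within the scatter), which would stay within the scatter. For compound 3 the estimated value in this assay is 3.5 nM, with an expected range of 1.2 nM to 10 nM.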

Compound 3, half-maximal inhibitory concentration: 3.1 nM
For compound 3 the middle estimate is 1.1-fold (0.05 log units) above the measured one; low and high end bracket the measured number.
By their numbers in this assay, from the lowest: compounds 2, 3 and 1 (each within the scatter of the next).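

In this assay, the series now has its first step between compounds that differ in one place: drawing the double bond as Z gives no change at the digits printed from compound 2 to compound 3 (within the scatter). Compound 1 could not show this, as it differs from compound 2 in more than the drawn configuration, so this pair is the only direct view of this double bond, and no effect of the drawn configuration appears in it. The step cannot be read as a comparison of two defined geometries, however, because what compound 2 contains at this double bond is left undefined by its drawing: the fact that one of compounds 2 and 3 is drawn with a defined configuration and the other without, at the place where they differ.

The compounds shown leave open whether the E form with the same fluorine-bearing group would also stay within the scatter of compound 3, since the only other configuration drawn, in compound 1, comes with a different substituent. They also leave open how the number responds when the shared core itself changes, for example with a carbonyl in place of the thiocarbonyl, or when a carboxylic acid or an amine takes the place of the fluorine.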